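A few compounds are considered here, and "the series" means these few. Any claim that something is new, unique, unknown or untested is made for them only; others in the source may bear on it.

The measured compounds in a functional assay on isolated protein for antagonist activity at C-C chemokine receptor type 9 (Homo sapiens), read by calcium flux, with a stated time of 10 min; a higher number here means a weaker inhibitor, a lower number a stronger inhibitor:
Compound 1 `COc1ccnc(-c2cc(Cl)ccc2NS(=O)(=O)c2ccc(C(C)(C)C)cc2)c1` gives 2500 nM.
Compound 2 `COc1cccnc1-c1cc(Cl)ccc1NS(=O)(=O)c1ccc(C(C)(C)C)cc1` gives 958 nM.
Compound 3 `CC(C)(C)c1ccc(S(=O)(=O)Nc2ccc(Cl)cc2-c2c(O)ccc[n+]2[O-])cc1` gives 491 nM.

Among these three numbers compound 2 stands second highest: its nearest neighbour is compound 3, with a 2.0-fold lower number from compound 2 to compound 3 (0.29 log units; within the scatter), and the furthest is compound 1, with a 2.6-fold lower number from compound 1 to compound 2 (0.42 log units; beyond the scatter). Compound 4 `CC(C)(C)c1ccc(S(=O)(=O)Nc2ccc(Cl)cc2-c2nccc(CO)c2O)cc1` differs from compound 2 in one place: a group of 9 heavy atoms (6 carbon, 1 nitrogen, 2 oxygen; one six-membered aromatic ring with 1 hetero atom) in place of a group of 8 heavy atoms (6 carbon, 1 nitrogen, 1 oxygen; one six-membered aromatic ring with 1 hetero atom), on an aromatic carbon. Going by the values given here, two measured steps bear on this. The step of a 2.6-fold lower number from compound 1 to compound 2 (0.42 log units; beyond the scatter) moved the methoxy group around its ring and was modest; the step of a 2.0-fold lower number from compound 2 to compound 3 (0.29 log units; within the scatter) exchanged the methoxy-bearing ring for a hydroxyl-bearing one and stayed within the scatter. Among the compounds with values here, no measured step tells what the hydroxymethyl group does. The expectation for compound 4 in this assay is therefore a 1.5-fold lower number from compound 2 to compound 4 (0.17 log units; within the scatter), a small shift at most. Compound 4 is estimated at 650 nM, with a range of 200 nM to 2000 nM.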

Compound 4, half-maximal inhibitory concentration: 8.7 nM
Compound 4: the middle estimate sits 75-fold (1.87 log units) above what was measured; measured number below the stated range.
By their numbers in this assay, from the lowest: compound 4; then compounds 3 and 2 (each within the scatter of the next); then compound 1.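

Going by these compounds alone, the ring on this aromatic carbon matters far more than the earlier compounds suggested: in this assay, the ring bearing both hydroxyl and hydroxymethyl groups gives a 110-fold lower number from compound 2 to compound 4 (2.04 log units; beyond the scatter), as well as a 56-fold lower number from compound 3 to compound 4 (1.75 log units; beyond the scatter) and (a 290-fold lower number from compound 1 to compound 4 (2.46 log units; beyond the scatter)). Compound 3 also has a hydroxyl on this ring but no hydroxymethyl, and its number stays far higher. Nothing available explains this large difference.

The compounds shown cannot separate the contribution of the hydroxymethyl group from that of the hydroxyl. As far as these compounds go, it also remains open how an aminomethyl group, a carboxylic acid or a longer hydroxyalkyl chain would behave in place of the hydroxymethyl.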